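Series notes: amine variation on the shared core

The compounds below may be only part of what the source reports. "The series", "measured", "known", "first", "only" and "open" are said of these compounds alone.

Of the compounds shown here, two have so far been measured in a functional assay on PC-3 cells (Homo sapiens) for antiproliferative activity, read by MTT assay, with a stated time of 72 h; a higher number here means a weaker inhibitor, a lower number a stronger inhibitor. Compound 1 `CN1CCN(C(=S)SCC2=CCOC2=O)CC1` gives 40500 nM in this assay. Compound 2 `O=C1OCC=C1CSC(=S)NC1CC1` gives 117000 nM in this assay, the higher of the two numbers recorded; the gap to compound 1 lies beyond the scatter, so compound 2 stands as the weaker of the pair on these data. Compound 3 `CC(C)NC(=S)SCC1=CCOC1=O` has not yet been measured. It differs from compound 2 by isopropyl in place of cyclopropyl on an amide-type nitrogen, a swap of one three-carbon group for another on the amide-type nitrogen, leaving the rest of the molecule unchanged. Among the measured compounds shown here, no measured pair maps this particular change, so nothing on record tells its size or direction. Given that the two measured compounds already span only a modest range in this assay, the expectation for the exchange is a step of no more than the scatter, in either direction, with an expected step of a 1.2-fold lower number from compound 2 to compound 3 (0.07 log units; within the scatter). Compound 3 is therefore expected to give about 100000 nM in this assay, with a range of 40000 nM to 250000 nM.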

Compound 3, half-maximal inhibitory concentration: 49400 nM
The estimate for compound 3 lay 2.0-fold (0.31 log units) above the measured number; measured number inside the range.
By their numbers in this assay, from the lowest: compounds 1 and 3 (each within the scatter of the next); then compound 2.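

Replacing cyclopropyl with isopropyl on the amide-type nitrogen gives, in this assay, a 2.4-fold lower number from compound 2 to compound 3 (0.37 log units; beyond the scatter), so this position is not indifferent to the choice between these two groups, and the change is now known in size and direction. Both groups hold the same count of carbon atoms, and neither adds a hydrogen-bond donor, a hydrogen-bond acceptor or a net charge; of the computed differences, only the three-membered ring that leaves with cyclopropyl separates them. The read-out at this nitrogen can therefore shift beyond the scatter under a swap that leaves those counts unchanged, although the step itself remains modest, and nothing on record gives a cause for it.

A single pair cannot separate the loss of the ring from the arrival of the branched group, so n-propyl on the same nitrogen would be the informative comparison for isopropyl and cyclopropyl. Going by these compounds, it also remains open how larger groups on this nitrogen, such as cyclobutyl, cyclohexyl or a longer chain like n-butyl, would read in this assay.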